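The source may hold more compounds than are shown below. What is called first, only, known or untested is meant among the compounds shown, and "the series" means these compounds.

Measured compounds:
Compound 1, `COc1cc2c(cc1OC)C(=O)/C(=C/c1ccc(CN(C)Cc3ccccc3)c(O)c1)O2`, gives 19.4% in an assay on cells for inhibition of Amine oxidase [flavin-containing] A (Homo sapiens), read by fluorescence, with a stated time of 30 min, tested at 10 uM; a higher number here means more inhibition at the concentration tested (going by the name of the read-out), a lower number less inhibition.
Compound 2, `CCN(Cc1ccccc1)Cc1ccc(/C=C2\Oc3cc(OC)c(OC)cc3C2=O)cc1O`, gives 17% in this assay.
Compound 3, `COc1cc2c(cc1OC)C(=O)/C(=C/c1cccc(O)c1)O2`, gives 17.2% in this assay.

Compound 3 stands second highest of the three numbers; its nearest neighbour is compound 2, a number 0.2 percentage points higher from compound 2 to compound 3 (within the scatter), and its furthest is compound 1, a number 2.2 percentage points lower from compound 1 to compound 3 (within the scatter), so all three sit within the scatter of one another. The step from compound 1 to compound 2, a number 2.4 percentage points lower from compound 1 to compound 2 (within the scatter), is likewise within the scatter.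

Compound 4, `COc1cc2c(cc1OC)C(=O)/C(=C/c1ccc(O)cc1)O2`, is still to be measured in this assay. It differs from compound 3 as follows: 4-hydroxyphenyl in place of 3-hydroxyphenyl on a double-bonded chain carbon bound to a double-bonded ring carbon. Going by the values given here, none of the measured steps moves a hydroxyl on this ring; the measured steps all touch the amine side chain, and each of them was within the scatter. There is therefore no direct guide to the size of the step from compound 3 to compound 4 in this assay, and nothing in the measured set points to a change beyond the scatter in either direction. The estimate for compound 4 is 17%, with a range from 4% to 32%, which means an expected step of a number 0.2 percentage points lower from compound 3 to compound 4 (within the scatter).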

Compound 4, a percentage reported as inhibition, at one concentration (the size of the read-out at that concentration, not a potency): 12.1%
Beside the measured number, compound 4's estimate is 4.9 percentage points above it; the measured number falls inside the stated range.
By their numbers in this assay, from the lowest: compounds 4, 2, 3 and 1 (each within the scatter of the next).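

Going by these compounds alone, this is the first measured change to the hydroxyl on the ring carried by the double-bonded chain carbon, as the earlier steps all touched the amine side chain. Putting 4-hydroxyphenyl in place of 3-hydroxyphenyl in this assay gives a number 5.1 percentage points lower from compound 3 to compound 4 (within the scatter), so these two isomeric groups cannot be told apart in this assay, although this step is larger than those printed for the side chain. No available evidence bears on the size of this step.

The compounds shown leave open whether a methoxy group, a carboxylic acid or an amine in place of this hydroxyl would give a step beyond the scatter. They also leave open how the 4-hydroxyphenyl group would behave alongside the benzyl(methyl)amino side chain of compound 1.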